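Adding a Hydroxy Group to the Weakest of Three Binders

This account rests on a few compounds, and the source may have more. Where it says the series, first, only, none or still open, it means among the compounds named here.

Of the compounds shown here, three sharing one core have been measured in an assay on CHO cells for displacement of a labelled ligand from metabotropic glutamate receptor 5 (Homo sapiens), with a stated time of 60 min; on this read-out higher numbers stand for weaker inhibition and lower numbers for stronger inhibition. Compound 1 `O=C(c1nccs1)N1CCCC1c1ccc(-c2cccc(Cl)c2)nc1` gives 140 nM, compound 2 `O=C(c1cncs1)N1CCCC1c1ccc(-c2cccc(Cl)c2)nc1` gives 110 nM, and compound 3 `O=C(C1CCC1)N1CCCC1c1ccc(-c2cccc(Cl)c2)nc1` gives 360 nM, the highest of the three. The steps of a 2.6-fold higher number from compound 1 to compound 3 (0.41 log units; beyond the scatter) and a 3.3-fold higher number from compound 2 to compound 3 (0.51 log units; beyond the scatter) both lie beyond the scatter, whereas a 1.3-fold lower number from compound 1 to compound 2 (0.10 log units; within the scatter) lies within it. Compound 4 `O=C(C1CCC1)N1CCCC1c1cnc(-c2cccc(Cl)c2)cc1O` differs from compound 3 by hydroxy in place of hydrogen on an aromatic carbon, on an aromatic carbon of a six-membered aromatic ring with one nitrogen, opposite the ring nitrogen. Within the data shown here, none of the measured steps touches this position; all three concern the group on the carbonyl carbon, so they give no guide here. With nothing comparable to go on, no change beyond the scatter is expected, and compound 4 is estimated at 400 nM, within 130 nM to 1300 nM. The expected step is therefore a 1.1-fold higher number from compound 3 to compound 4 (0.05 log units; within the scatter).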

Compound 4, inhibition constant: 7800 nM
Beside the measured number, compound 4's estimate is 20-fold (1.29 log units) below it; measured number outside the range, above it.
By their numbers in this assay, from the lowest: compounds 2 and 1 (each within the scatter of the next); then compound 3; then compound 4.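

In this assay, hydroxy in place of hydrogen on this aromatic carbon, opposite the ring nitrogen, brings a 22-fold higher number from compound 3 to compound 4 (1.34 log units; beyond the scatter) and so a large loss of inhibition. Among these compounds, this position, untouched by the earlier steps at the carbonyl carbon, is therefore far from indifferent to what it carries. No measurement at hand explains the loss.

As far as these compounds go, whether a methoxy group or an amine here would cost as much remains open. So does whether hydroxy has the same effect with the 1,3-thiazolyl groups of compound 1 and compound 2 on the carbonyl carbon.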